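Ether variation on the shared core: compound 2 toward compound 4

This account rests on a few compounds, and the source may have more. Where it says the series, first, only, none or still open, it means among the compounds named here.

Measured so far:
- compound 1 `COCCOCCOCCO[C@@H]1C=CC(=O)[C@@H](CO)O1`: in a functional assay on NCI-H292 cells (Homo sapiens) for inhibition, read by MTT assay, with a stated time of 72 h (a lower number here means a stronger inhibitor, a higher number a weaker inhibitor), compound 1 gives 35500 nM
- compound 2 `CC(C)O[C@@H]1C=CC(=O)[C@@H](CO)O1`: in this assay compound 2 gives 24200 nM
- compound 3 `O=C1C=C[C@@H](OCc2ccccc2)O[C@@H]1CO`: in this assay compound 3 gives 3800 nM

Working notes. The three measured compounds share one core and differ only in the group carried on the same oxygen. Compound 2 holds the second highest of the three numbers. Its nearest neighbour is compound 1, whose value sits within the usual scatter of that of compound 2, so no order between these two is claimed. Compound 3 lies furthest away, with a lower number than compound 2 by a margin well beyond the scatter.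

Compound 4 `CCCO[C@@H]1C=CC(=O)[C@@H](CO)O1` awaits measurement. Against compound 2 the change is propyl in place of isopropyl on an oxygen on a saturated carbon; cut one bond further out, it reads isopropoxy to propoxy. Within the data shown here, no step between measured compounds is on hand for such a change. Since compound 1 with 35500 nM and compound 2 with 24200 nM stay within the scatter of each other despite a larger difference in the group on that oxygen, the expectation for this assay is a step no larger than the scatter, in no particular direction.

Compound 4 is therefore expected at 22000 nM, with a range from 10000 nM to 48000 nM. The step from compound 2 that this estimate means is expected to be a 1.1-fold lower number from compound 2 to compound 4 (0.04 log units; within the scatter).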

Compound 4, half-maximal inhibitory concentration: 15600 nM
Beside the measured number, compound 4's estimate is 1.4-fold (0.15 log units) above it; measured number inside the range.
By their numbers in this assay, from the lowest: compound 3; then compounds 4, 2 and 1 (each within the scatter of the next, the first and the last beyond it).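

In this assay, among these compounds, the first step at this oxygen with atoms unchanged, propyl in place of isopropyl, gives a 1.6-fold lower number from compound 2 to compound 4 (0.19 log units; within the scatter), so the two arrangements of a three-carbon group are not separated here. The new value also stretches the cluster of simple ethers: compound 4 stands within the scatter of compound 2 and compound 2 within that of compound 1, yet compound 4 at 15600 nM and compound 1 at 35500 nM lie beyond the scatter of each other, while compound 3 at 3800 nM keeps the lowest number in this assay. No measurement on hand accounts for any of these values.

Still open, from the compounds shown here alone, is what sets the benzyl group of compound 3 apart from the propyl group of compound 4, which a phenyl ring placed on a longer chain, or a plain butyl or hexyl chain of similar size, could begin to separate. Also open, going by these compounds, is how a chain ending in an amine or a carboxylic acid would read on this oxygen, since the only chain with further oxygens, that of compound 1, gives the highest number of the four.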